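The source may hold more compounds than are shown below. What is called first, only, known or untested is meant among the compounds shown, and "the series" means these compounds.

Going by the values given here, in a physicochemical assay for lipophilicity, at pH 7.4 (on this read-out lower numbers stand for lower lipophilicity and higher numbers for higher lipophilicity), only two compounds have been measured so far. Compound 1 (`CCNC(=O)C1CCN(c2cncnc2-c2ccccc2)CC1`) gives 1.8 and compound 2 (`CN(C)C(=O)C1CCN(c2cnccc2-n2cccn2)CC1`) gives 1.1 as the lower of the two numbers, a gap that lies beyond the usual scatter of such measurements. Among the compounds with values here, these two compounds differ in more than one place, so the set holds no measured single-change step to serve as a guide.

Compound 3 (`Cc1cnc(-c2ccncc2N2CCC(C(=O)N(C)C)CC2)s1`) departs from compound 2 at one place only (5-methyl-1,3-thiazol-2-yl in place of 1H-pyrazol-1-yl on an aromatic carbon) and the change sits ortho to a large group, opposite the ring nitrogen. Neither the entering group nor the leaving group appears in any measured pair, so the expectation rests on the structural change alone and the range is kept wide.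

An upward move beyond the scatter is expected, and the estimate in this assay is a number 0.90 log units higher from compound 2 to compound 3 (beyond the scatter) for this change. Compound 3 is therefore expected at 2 (estimated range 1.6 to 2.4) once it is measured.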

Compound 3, distribution coefficient: 2
Beside the measured number, compound 3's estimate shows no gap at the digits printed; low and high end bracket the measured number.
By their numbers in this assay, from the lowest: compound 2; then compounds 1 and 3 (each within the scatter of the next).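

In this assay, the set now holds its first single-change step, and it gives a number 0.90 log units higher from compound 2 to compound 3 (beyond the scatter) when 5-methyl-1,3-thiazol-2-yl takes the place of 1H-pyrazol-1-yl. The read-out therefore responds to the choice of five-membered aromatic ring on this aromatic carbon, ortho to a large group and opposite the ring nitrogen, even though the two groups have the same counts of hydrogen-bond donors and acceptors and neither carries a net charge. Nothing at hand explains the size of this step, so it stands as an observation for this one pair of compounds.

The compounds shown leave open how the step divides between the methyl group and the change of ring, as the entering group differs from the leaving group in both, and a plain 1,3-thiazol-2-yl at the same place would separate the two. They also leave open how the read-out would respond to a group of another kind on this carbon, such as an amine or a methoxy group.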